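Carboxylate position on the phenoxymethyl arm of the shared core

The source may report more compounds than this note shows. Statements on the series, on what has been measured and on what is new or still open speak of the compounds shown alone.

Measured compounds in a functional assay on HEK293 cells for agonist activity at Bile acid receptor (Homo sapiens), read by a luciferase reporter; on this read-out higher numbers stand for an effect only at larger amounts of compound and lower numbers for an effect already at smaller amounts:
compound 1 `CN(Cc1cccc(C(=O)O)c1)c1ccc(OCc2c(-c3c(Cl)cccc3Cl)noc2C2CC2)nc1C(F)(F)F`, 2 nM
compound 2 `O=C(O)c1ccccc1OCc1ccc(OCc2c(-c3c(Cl)cccc3Cl)noc2C2CC2)nc1C(F)(F)F`, 611 nM

Going by the values given here, compound 2 stands at the highest of the two numbers in this assay; its nearest neighbour is compound 1, and the single measured step, a 310-fold higher number from compound 1 to compound 2 (2.49 log units; beyond the scatter), is large. That step changes two things at once, the linking group and the position of the carboxylate on the aromatic ring, so it does not isolate either.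

Compound 3 `O=C(O)c1cccc(OCc2ccc(OCc3c(-c4c(Cl)cccc4Cl)noc3C3CC3)nc2C(F)(F)F)c1` is not yet measured. It differs from compound 2 by 3-carboxyphenyl in place of 2-carboxyphenyl on an oxygen on a saturated carbon. Among the compounds with values here, no measured step bears on this change alone; the only comparison available is that compound 1, with its 3-carboxybenzyl group, gives 2 nM while compound 2, with a 2-carboxyphenoxy group, gives 611 nM. That comparison is confounded by the linker and so carries limited weight here.

Given the large gap from compound 1 to compound 2 and the shared 3-carboxy placement between compound 1 and compound 3, a step toward a lower number is expected, a 5.1-fold lower number from compound 2 to compound 3 (0.71 log units; beyond the scatter), but of uncertain size.

Compound 3 is estimated at 120 nM, range 15 nM to 1000 nM.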

Compound 3, half-maximal effective concentration: 33 nM
Beside the measured number, compound 3's estimate is 3.6-fold (0.56 log units) above it; the range from low to high includes it.
By their numbers in this assay, from the lowest: compound 1; then compound 3; then compound 2.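

With the phenoxymethyl arm held constant in this assay, changing 2-carboxyphenyl to 3-carboxyphenyl on the oxygen gives a 19-fold lower number from compound 2 to compound 3 (1.27 log units; beyond the scatter) and thus isolates the carboxylate position as a change that matters on its own, which the earlier confounded step could not do. With 3-carboxy placement shared, (3-carboxyphenoxy)methyl in place of (3-carboxybenzyl)(methyl)amino on the aromatic carbon gives a 17-fold higher number from compound 1 to compound 3 (1.22 log units; beyond the scatter) in this assay and shows that the change of linking group also matters, independently of where the carboxylate sits. The large gap first seen between compound 1 and compound 2 therefore resolves into two separate steps, each beyond the scatter, but no measurement here gives a reason for either one.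

As far as these compounds go, all three compounds carry a carboxylic acid, so it remains open whether a primary amide or a tetrazole on the same ring would keep the number of compound 3 or that of compound 1. Also open, from the compounds shown here alone, is how a longer chain between the ether oxygen and the carboxyphenyl ring, or a secondary amine in place of the methylamino link, would read in this assay on this core.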